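The source may hold more compounds than are shown below. What is called first, only, known or untested is meant among the compounds shown, and "the series" means these compounds.

Measured in a functional assay on CHO cells with adenosine receptor A1 (Homo sapiens) as the target, read by cAMP accumulation and immunoassay, with a stated time of 6 min, tested at 10 uM; on this read-out lower numbers stand for a stronger effect and higher numbers for a weaker effect at the one concentration tested:

- compound 1, `Nc1scc(CN2CCN(c3cccc(Cl)c3Cl)CC2)c1C(=O)c1ccc(Cl)cc1`: -77%
- compound 2, `Nc1scc(CN2CCN(c3ccc(Cl)cc3F)CC2)c1C(=O)c1ccc(Cl)cc1`: -81%
- compound 3, `Nc1scc(CN2CCN(c3ccccc3F)CC2)c1C(=O)c1ccc(Cl)cc1`: -15%

Compound 3 gives the highest of the three numbers in this assay. Its nearest neighbour is compound 1, reached by a number 62 percentage points higher from compound 1 to compound 3 (beyond the scatter), and the furthest is compound 2, reached by a number 66 percentage points higher from compound 2 to compound 3 (beyond the scatter); both gaps lie beyond the scatter. Compounds 1 and 2 themselves sit within the scatter of each other, as shown by a number 4 percentage points lower from compound 1 to compound 2 (within the scatter).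

Compound 4, `Nc1scc(CN2CCN(c3cccc(Cl)c3)CC2)c1C(=O)c1ccc(Cl)cc1`, is not yet measured. Its difference from compound 3 is 3-chlorophenyl in place of 2-fluorophenyl on an amine nitrogen in a ring.

Among the measured compounds shown here, two measured steps bear on this change, and both end in compound 3: a number 62 percentage points higher from compound 1 to compound 3 (beyond the scatter) and a number 66 percentage points higher from compound 2 to compound 3 (beyond the scatter). In each of them a chloro left the phenyl on the ring nitrogen and the number rose by a large amount. Compound 4 brings a chloro onto that phenyl again, as 3-chlorophenyl, while the fluorine of 2-fluorophenyl leaves. For the measured compounds named here, a large step downward from compound 3 is therefore expected, with a wide range because no compound so far carries 3-chlorophenyl alone. For compound 4 the estimated value in this assay is -60%, expected to lie between -85% and -25%. This estimate corresponds to an expected step of a number 45 percentage points lower from compound 3 to compound 4 (beyond the scatter).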

Compound 4, a percentage reported as activity, at one concentration (the size of the read-out at that concentration, not a potency): -77%
Beside the measured number, compound 4's estimate is 17 percentage points above it, within the range that was stated.
By their numbers in this assay, from the lowest: compounds 2, 1 and 4 (each within the scatter of the next); then compound 3.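

In this assay, 3-chlorophenyl in place of 2-fluorophenyl on the amine nitrogen in the ring gives a number 62 percentage points lower from compound 3 to compound 4 (beyond the scatter), the first sign that one chloro on this phenyl, with no fluorine, is enough to leave the level of compound 3. The further chloro of 2,3-dichlorophenyl adds nothing that can be read, with no change at the digits printed from compound 1 to compound 4 (within the scatter), and 3-chlorophenyl cannot be told apart from 4-chloro-2-fluorophenyl, with a number 4 percentage points higher from compound 2 to compound 4 (within the scatter). Taking a chloro off this phenyl therefore has no single effect of fixed size, and the outcome changes with the rest of the substitution on the phenyl: the same change on two cores in this assay, a number 66 percentage points higher (beyond the scatter) from compound 2 to compound 3 and no change at the digits printed (within the scatter) from compound 1 to compound 4, 66 percentage points apart, beyond the scatter of two such steps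

Open, as far as these compounds go, is whether the chloro of 3-chlorophenyl can give way to a methoxy or trifluoromethyl group with the number held at this level. Also open, from the compounds shown here alone, is whether compounds 1, 2 and 4 differ in the strength of their effect at the one concentration tested: these three lie within the scatter of one another.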